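This account rests on a few compounds, and the source may have more. Where it says the series, first, only, none or still open, it means among the compounds named here.

Measured compounds: compound 1 `N#Cc1cccc(Cc2cnc(CCc3ccc(-c4ccccc4C(=O)O)cc3)[nH]2)c1` with 20 nM; compound 2 `CCC(C)(CC)Cc1cnc(CCc2ccc(-c3ccccc3C(=O)O)cc2)[nH]1` with 30 nM; compound 3 `O=C(O)c1ccccc1-c1ccc(CCc2ncc(Cc3cccc(F)c3F)[nH]2)cc1` with 8 nM, all in an in vitro functional assay on cells for agonist activity at Bombesin receptor subtype-3 (Mus musculus), read by luminescence and calcium flux; on this read-out lower numbers stand for an effect already at smaller amounts and higher numbers for an effect only at larger amounts of compound.

Compound 3 has the lowest of the three numbers in this assay, separated from the others by a 2.5-fold lower number from compound 1 to compound 3 (0.40 log units; beyond the scatter) and a 3.8-fold lower number from compound 2 to compound 3 (0.57 log units; beyond the scatter), both beyond the scatter. Compound 4 `O=C(O)c1ccccc1-c1ccc(CCc2ncc(Cc3cccc(Cl)c3)[nH]2)cc1` differs from compound 3 in one place: 3-chlorophenyl in place of 2,3-difluorophenyl on a saturated chain carbon bound to an aromatic carbon. The step that bears most on this change is a 2.5-fold lower number from compound 1 to compound 3 (0.40 log units; beyond the scatter), where another substituted phenyl on the same chain carbon gave a modestly higher number than the 2,3-difluorophenyl; compound 2 shows a similar direction. Compound 4 is therefore expected to read somewhat higher than compound 3, with a 1.9-fold higher number from compound 3 to compound 4 (0.27 log units; within the scatter) judged close to the edge of the scatter. The estimate for compound 4 in this assay is 15 nM, within 5 nM to 45 nM.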

Compound 4, half-maximal effective concentration: 31 nM
For compound 4 the middle estimate is 2.1-fold (0.32 log units) below the measured one; measured number inside the range.
By their numbers in this assay, from the lowest: compound 3; then compounds 1, 2 and 4 (each within the scatter of the next).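

In this assay the 2,3-difluorophenyl now stands apart from a second substituted phenyl on this chain carbon, with a 3.9-fold higher number from compound 3 to compound 4 (0.59 log units; beyond the scatter) for the change to 3-chlorophenyl. Chloro in place of cyano gives a 1.6-fold higher number from compound 1 to compound 4 (0.19 log units; within the scatter) and 3-chlorophenyl in place of 1-ethyl-1-methylpropyl gives a 1.0-fold higher number from compound 2 to compound 4 (0.01 log units; within the scatter) within the scatter, so among compounds 1, 2 and 4 the number does not follow the group, and compound 3 goes against this. The compounds shown leave open whether a single fluorine, as in 3-fluorophenyl or 2-fluorophenyl, is enough to give the number of compound 3. Nothing available here explains these differences.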